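Swapping the Dihydroxyphenyl Arm: An Expectation for Compound 4

The source may report more compounds than this note shows. Statements on the series, on what has been measured and on what is new or still open speak of the compounds shown alone.

Three analogues built on one shared core have been measured in a functional assay on SW-620 cells (Homo sapiens) for antiproliferative activity, read by MTT assay, with a stated time of 72 h; on this read-out lower numbers stand for stronger inhibition and higher numbers for weaker inhibition. Compound 1, `COc1cc(/C=C2\CCC/C(=C\c3ccccc3F)C2=O)cc(OC)c1OC`, gives 2100 nM. Compound 2, `COc1cc(/C=C2\CCC/C(=C\c3ccc(F)c(F)c3)C2=O)cc(OC)c1OC`, gives 4100 nM, and compound 3, `COc1cc(/C=C2\CCC/C(=C\c3ccc(O)c(O)c3)C2=O)cc(OC)c1OC`, gives 3200 nM. Compound 3 stands second highest of the three numbers, with compound 2 nearest and compound 1 furthest, yet every gap among these compounds lies within the scatter: a 2.0-fold higher number from compound 1 to compound 2 (0.29 log units; within the scatter), a 1.5-fold higher number from compound 1 to compound 3 (0.18 log units; within the scatter) and a 1.3-fold lower number from compound 2 to compound 3 (0.11 log units; within the scatter).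

Compound 4, `COc1ccccc1/C=C1\CCC/C(=C\c2cc(OC)c(OC)c(OC)c2)C1=O`, remains to be tested. It differs from compound 3 in one place: 2-methoxyphenyl in place of 3,4-dihydroxyphenyl on a double-bonded chain carbon bound to a double-bonded ring carbon. The measured steps that bear on this change are the ones in which the aryl group on that double-bonded chain carbon was varied. Among the measured compounds shown here, the closest precedent is compound 1, whose 2-fluorophenyl group resembles the incoming 2-methoxyphenyl of compound 4; the step of a 1.5-fold higher number from compound 1 to compound 3 (0.18 log units; within the scatter) stayed within the scatter, as did a 1.3-fold lower number from compound 2 to compound 3 (0.11 log units; within the scatter). Three different aryl groups at this position thus gave numbers indistinguishable from one another.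

On this basis no step beyond the scatter is expected in this assay, and the expected step is a 1.2-fold lower number from compound 3 to compound 4 (0.09 log units; within the scatter). Compound 4 is estimated at 2600 nM, with an expected range from 1100 nM to 6500 nM.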

Compound 4, half-maximal inhibitory concentration: 2000 nM
The estimate for compound 4 lay 1.3-fold (0.11 log units) above the measured number, within the range that was stated.
By their numbers in this assay, from the lowest: compounds 4, 1, 3 and 2 (each within the scatter of the next, the first and the last beyond it).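

In this assay, the change at this position now produces a step beyond the scatter, though only a modest one and only against the 3,4-difluorophenyl group (a 2.1-fold lower number from compound 2 to compound 4 (0.31 log units; beyond the scatter)). The other two steps stay within the scatter: 2-methoxyphenyl, with 0 hydrogen-bond donors, cannot be told apart from the 3,4-dihydroxyphenyl group (a 1.6-fold lower number from compound 3 to compound 4 (0.20 log units; within the scatter)), and methoxy in place of fluoro on an aromatic carbon also leaves the two compounds indistinguishable (a 1.1-fold lower number from compound 1 to compound 4 (0.02 log units; within the scatter)), so neither the loss of those donors nor this exchange registers in this read-out. Nothing shown here gives a measured reason for any of these steps.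

Going by these compounds, all four compounds carry a six-membered aromatic ring of carbon at this place, so it remains open whether an amine or a carboxylic acid on that ring, or a longer chain in place of the ring, would give a step clearly beyond the scatter. On these data alone, it is also open whether the modest step seen here would hold if the other arm of the shared core were changed, or in any cell line other than the one used here.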